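The source may hold more compounds than are shown below. What is called first, only, known or untested is meant among the compounds shown, and "the series" means these compounds.

Measured compounds:
compound 1 `COc1cc2c(Oc3ccc(NC(=O)c4cc(-c5ccc(F)cc5)ccn4)cc3F)ccnc2cc1OCCCN1CCN(C)CC1`, 1460 nM
compound 2 `COc1cc2c(Oc3ccc(NC(=O)c4cc(-c5ccc(C(F)(F)F)cc5)ccn4)cc3F)ccnc2cc1OCCCN1CCN(C)CC1`, 200 nM

Among the measured compounds shown here, in a functional assay on HT-29 cells (Homo sapiens) for cytotoxicity, read by MTT assay, with a stated time of 72 h (a higher number here means a weaker inhibitor, a lower number a stronger inhibitor), compound 2 gives the lowest number of the two; the nearest is compound 1, and the only step at hand is a 7.3-fold lower number from compound 1 to compound 2 (0.86 log units; beyond the scatter). Compound 3 `COc1ccc(-c2ccnc(C(=O)Nc3ccc(Oc4ccnc5cc(OCCCN6CCN(C)CC6)c(OC)cc45)c(F)c3)c2)c(OC)c1` differs from compound 2 by 2,4-dimethoxyphenyl in place of 4-(trifluoromethyl)phenyl on an aromatic carbon, on an aromatic carbon meta to a large group, opposite the ring nitrogen. For the measured compounds named here, no measured step bears on this exchange directly; the one step seen concerns a different group, so the outlook is uncertain. Compound 3 is expected to land at 600 nM (range 150 nM to 2500 nM), a step of a 3.0-fold higher number from compound 2 to compound 3 (0.48 log units; beyond the scatter).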

Compound 3, half-maximal inhibitory concentration: 420 nM
The estimate for compound 3 lay 1.4-fold (0.15 log units) above the measured number, and the stated range covers the measured number.
By their numbers in this assay, from the lowest: compound 2; then compound 3; then compound 1.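

In this assay, 2,4-dimethoxyphenyl in place of 4-(trifluoromethyl)phenyl gives a 2.1-fold higher number from compound 2 to compound 3 (0.32 log units; beyond the scatter) and, in place of 4-fluorophenyl, gives a 3.5-fold lower number from compound 1 to compound 3 (0.54 log units; beyond the scatter) on the same aromatic carbon. This position therefore accepts a ring bearing oxygen substituents, and compound 3 ranks second of the three, so 4-(trifluoromethyl)phenyl remains the best group seen here. No measurement available here explains either step.

Which methoxy group drives the difference stays open. So does the outcome with a single methoxy group, a dimethylamino group or a carboxylic acid on this ring.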